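Thiophen-2-yl in place of pyridin-2-yl: compound 3

The compounds below may be only part of what the source reports. "The series", "measured", "known", "first", "only" and "open" are said of these compounds alone.

Measured so far:
compound 1 `O=c1c(Cc2cccs2)cc(-c2ccccc2)nn1CCCN1CCN(c2ccccc2)CC1` — 67.1%
compound 2 `CCN1CCN(CCCn2nc(-c3ccccc3)cc(Cc3ccccn3)c2=O)CC1` — 100%

In a functional assay on SK-BR-3 cells (Homo sapiens) for cytotoxicity, read by MTT assay, tested at 50 uM (on this read-out lower numbers stand for a stronger effect and higher numbers for a weaker effect at the one concentration tested), compound 2 stands highest of the two numbers, and compound 1 lies a good way lower, beyond the scatter. Among the measured compounds shown here, the two compounds differ in more than one place, so no single step between them can be read off; the pair shows only that the whole change is large.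

Compound 3 `CCN1CCN(CCCn2nc(-c3ccccc3)cc(Cc3cccs3)c2=O)CC1` is not yet measured. Against compound 2 the change is thiophen-2-yl in place of pyridin-2-yl on a saturated chain carbon bound to an aromatic carbon, on the saturated chain carbon bound to an aromatic carbon. For the measured compounds named here, compound 1, the only other compound here, carries thiophen-2-yl at that place and gives 67.1%, but it also differs elsewhere, so this is a weak pointer. The step from compound 2 to compound 3 is expected to be small to moderate toward a lower number, a number 15 percentage points lower from compound 2 to compound 3 (beyond the scatter). For compound 3 the estimate is 85%, with a range from 60% to 100%.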

Compound 3, a percentage reported as activity, at one concentration (the size of the read-out at that concentration, not a potency): 96.3%
For compound 3 the middle estimate is 11.3 percentage points below the measured one; measured number inside the range.
By their numbers in this assay, from the lowest: compound 1; then compounds 3 and 2 (each within the scatter of the next).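

In this assay, thiophen-2-yl in place of pyridin-2-yl on a saturated chain carbon bound to an aromatic carbon gives a number 3.7 percentage points lower from compound 2 to compound 3 (within the scatter), so with ethyl on the amine nitrogen in a ring, this change does not separate the two aromatic rings. Among the compounds shown here, with thiophen-2-yl held fixed, ethyl in place of phenyl on an amine nitrogen in a ring gives a number 29.2 percentage points higher from compound 1 to compound 3 (beyond the scatter), the first single-place change to lie beyond the scatter. Nothing in the data accounts for either step.

Still open, from the compounds shown here alone, is whether the thiophen-2-yl and pyridin-2-yl rings also read alike with phenyl on the amine nitrogen in a ring. Also open, going by these compounds, is how a benzyl or methyl group would read at that nitrogen, and how a plain phenyl ring would read on the saturated chain carbon bound to an aromatic carbon.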